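Aminothiophene series: chloro on the benzylamide aromatic ring

This account rests on a few compounds, and the source may have more. Where it says the series, first, only, none or still open, it means among the compounds named here.

Three compounds of the shared core have numbers in an in vitro assay on CHOk1 cells with adenosine receptor A1 (Homo sapiens) as the target; a lower number here means that less compound is needed, a higher number that more compound is needed for the effect. Compound 1 `CCOC(=O)c1c(N)sc2c1CCNC2` gives 11700 nM. Compound 2 `Nc1sc2c(c1C(=O)O)CCN(Cc1ccccc1)C2` gives 8000 nM in this assay. Compound 3 `Nc1sc2c(c1C(=O)NCc1ccccc1)CCN(Cc1ccccc1)C2` gives 13100 nM in this assay, the highest of the three numbers, although its gaps to compound 1 and compound 2 are within the scatter, so no order among them can be read. Going by the values given here, the one single-point step so far, a 1.6-fold higher number from compound 2 to compound 3 (0.21 log units; within the scatter), is also within the scatter.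

Compound 4 `Nc1sc2c(c1C(=O)NCc1cccc(Cl)c1)CCN(Cc1ccccc1)C2` differs from compound 3 by chloro in place of hydrogen on an aromatic carbon. Among the compounds with values here, no measured step touches the aromatic ring of the benzylamide, so nothing in the three numbers speaks for or against a change here; the only measured step, from compound 2 to compound 3, stayed within the scatter, and the numbers of compound 1 and compound 2 show the same flat picture. For compound 4 the expected step is therefore a 1.1-fold lower number from compound 3 to compound 4 (0.04 log units; within the scatter), none beyond the scatter. Compound 4 is estimated at 12000 nM in this assay, within 4000 nM to 35000 nM.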

Compound 4, half-maximal effective concentration: > 20000 nM
Compound 4: no number, only a limit; the forecaster's own chance of this, stated with the estimate: 20%; middle value at least 1.6-fold (0.22 log units) from the limit.
By their numbers in this assay, from the lowest: compounds 2, 1 and 3 (each within the scatter of the next). At a limit, above all of these: compound 4.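

Compound 4 gives no number in this assay, only a limit of the assay: the limit of > 20000 nM in this assay, at which 1 of the 4 values shown sits.
On the aromatic ring of the benzylamide, chloro in place of hydrogen gives an at least 1.5-fold higher number from compound 3 to compound 4 (0.18 log units; that floor lies within the scatter), so this step alone cannot separate compound 4 from compound 3, although the limit leaves room for a larger gap. Going by these compounds alone, the comparison with the carboxylic acid gives the first step that clears the scatter: an at least 2.5-fold higher number from compound 2 to compound 4 (0.39 log units; beyond the scatter).

Going by these compounds, how far compound 4 lies past its limit stays open, as does whether the rise belongs to chloro itself or would also follow from another group at this place. Fluoro, methoxy or an amine on this ring, or a longer chain between the amide nitrogen and the ring, could show how much change this end of the molecule tolerates.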